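Sulfonyl urea series: removing the methyl from the amide nitrogen

A few compounds are considered here, and "the series" means these few. Any claim that something is new, unique, unknown or untested is made for them only; others in the source may bear on it.

Measured compounds:
compound 1 `Cc1ccc(S(=O)(=O)N(C)C(=O)NC(C)c2cc(Br)ccc2OC(C)C)cc1` — 34700 nM
compound 2 `CC(C)Oc1ccc(Br)cc1C(C)NC(=O)N(C)S(=O)(=O)c1ccc(Cl)cc1` — 43200 nM
compound 3 `Cc1ccc(S(=O)(=O)N(C)C(=O)NC(C)c2cc(Br)ccc2OCc2ccccc2)cc1` — 67100 nM

In a functional assay on thoracic aorta (Rattus norvegicus, strain Wistar), with a stated time of 15 min (a lower number here means that less compound is needed, a higher number that more compound is needed for the effect), compound 1 gives the lowest of the three numbers, but neither neighbour is separated from it: a 1.2-fold higher number from compound 1 to compound 2 (0.10 log units; within the scatter) and a 1.9-fold higher number from compound 1 to compound 3 (0.29 log units; within the scatter). Going by the values given here, both measured changes, chloro in place of methyl on an aromatic carbon and benzyl in place of isopropyl on an oxygen on the aromatic ring, leave the read-out essentially where it was, so the series so far is flat across the three compounds.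

Compound 4 `Cc1ccc(S(=O)(=O)NC(=O)NC(C)c2cc(Br)ccc2OC(C)C)cc1` is the next compound for this assay. Its difference from compound 1 is hydrogen in place of methyl on an amide-type nitrogen. Among the compounds with values here, no measured step touches the amide-type nitrogen, so nothing in the data bears directly on this change; the two measured steps concern other parts of the shared core and were both within the scatter. Within the data shown here, the only guide is the flatness of the series, which argues for no step beyond the scatter as the default, while the untested position keeps the range wide.

Compound 4 is therefore expected to give 32000 nM, within 8000 nM to 130000 nM. The expected step, a 1.1-fold lower number from compound 1 to compound 4 (0.04 log units; within the scatter), is an estimate resting on the flat series, not on a precedent for this change.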

Compound 4, half-maximal effective concentration: 61800 nM
Estimate against measurement, compound 4: 1.9-fold (0.29 log units) below; the measured number falls inside the stated range.
By their numbers in this assay, from the lowest: compounds 1, 2, 4 and 3 (each within the scatter of the next).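

In this assay, going by these compounds alone, hydrogen in place of methyl on the amide-type nitrogen whose other neighbours are the carbonyl carbon and the sulfonyl sulfur gives a 1.8-fold higher number from compound 1 to compound 4 (0.25 log units; within the scatter), the first reading for this position. The methyl on this nitrogen can therefore be exchanged for hydrogen without separating compound 4 from compound 1, and this nitrogen now joins the aromatic carbon and the oxygen substituent as a third place where one measured change stays within the scatter. Nothing available explains this step or bears on the result.

Still open is whether an ethyl group or a longer chain on this nitrogen would leave the read-out equally unmoved, since hydrogen and methyl are the only two substituents shown there. Also open, going by these compounds, is whether the same exchange would stay within the scatter on the core of compound 2 or compound 3, and whether any single change to the shared core, such as a carboxylic acid or an amine on the aromatic ring, can move the number beyond the scatter at all.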